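The compounds below may be only part of what the source reports. "The series", "measured", "known", "first", "only" and "open" are said of these compounds alone.

Measured compounds in a functional assay on DU-145 cells (Homo sapiens) for antiproliferative activity, read by MTT assay, with a stated time of 72 h; a lower number here means a stronger inhibitor, a higher number a weaker inhibitor:
- compound 1 `NC1CCc2nc(-c3ccncc3)nc(Nc3ccc(F)cc3)c2C1`: 10500 nM
- compound 2 `NC1CCc2nc(-c3ccncc3)nc(Nc3cccc(F)c3)c2C1`: 15100 nM

Going by the values given here, compound 1 gives the lowest of the two numbers in this assay, but the only neighbour, compound 2, sits a step of a 1.4-fold higher number from compound 1 to compound 2 (0.16 log units; within the scatter) away, so the two are not separated. Among the compounds with values here, that step is the one change at a nitrogen on an aromatic ring recorded so far: 3-fluorophenyl in place of 4-fluorophenyl.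

Compound 3 `COc1cccc(Nc2nc(-c3ccncc3)nc3c2CC(N)CC3)c1` is not yet measured. It differs from compound 1 by 3-methoxyphenyl in place of 4-fluorophenyl on a nitrogen on an aromatic ring. Within the data shown here, the only step that bears on it is the one from compound 1 to compound 2, which altered the same aryl group at the same place and stayed within the scatter. Among the measured compounds shown here, no substituent other than fluorine has been tried at this position, so a methoxy group entering carries no precedent. On that basis no step beyond the scatter is expected; the estimate for compound 3 is 12000 nM (range 4000 nM to 40000 nM), a step of a 1.1-fold higher number from compound 1 to compound 3 (0.06 log units; within the scatter) that is expected to stay near compound 1 in this assay.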

Compound 3, half-maximal inhibitory concentration: 8800 nM
The estimate for compound 3 lay 1.4-fold (0.13 log units) above the measured number; measured number inside the range.
By their numbers in this assay, from the lowest: compounds 3, 1 and 2 (each within the scatter of the next).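

Working notes on the aryl group on the aromatic nitrogen: in this assay, 3-methoxyphenyl is the first group at this place to carry something other than fluorine, and the comparison with 4-fluorophenyl gives a 1.2-fold lower number from compound 1 to compound 3 (0.08 log units; within the scatter). Methoxy in place of fluoro on an aromatic carbon gives a 1.7-fold lower number from compound 2 to compound 3 (0.23 log units; within the scatter), so this exchange of substituent, and not only a shift of the fluorine, leaves the numbers unseparated, even with one hydrogen-bond acceptor entering where 3-fluorophenyl has none. No supporting data bear on this result, so nothing can be said about what lies behind these numbers.

The three compounds therefore define no order at this place, and they do not show whether the aryl group matters in this assay at all. Open, as far as these compounds go, are an unsubstituted phenyl, a ring carrying a carboxylic acid or a dimethylamino group, and a longer chain such as butoxy in place of methoxy, any of which could test whether a step beyond the scatter is available here.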